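Aryl swap carried from compound 2 onto the core of compound 1

The source may report more compounds than this note shows. Statements on the series, on what has been measured and on what is new or still open speak of the compounds shown alone.

Measured so far:
- compound 1 `NC1=NC2(CCSCC2)N(OCCCOc2cc(Cl)c(Cl)cc2Cl)C(N)=N1`: in a functional assay on A549 cells (Homo sapiens) for antiproliferative activity, read by MTT assay, with a stated time of 72 h (a higher number here means a weaker inhibitor, a lower number a stronger inhibitor), compound 1 gives > 100000 nM, which is a limit of the assay and not a number.
- compound 2 `NC1=NC2(CCOCC2)N(OCCCOc2cc(Cl)c(Cl)cc2Cl)C(N)=N1`: in this assay compound 2 gives 680 nM.
- compound 3 `NC1=NC2(CCOCC2)N(OCCCOc2ccccc2Br)C(N)=N1`: in this assay compound 3 gives 160 nM.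

Compound 1 and compound 2 carry the same side chain and differ in the core; the difference between the two cores is not broken down here. Compound 2 gives a number, whereas compound 1 sits at the limit of > 100000 nM in this assay, at which 1 of the 3 values shown sits.

From compound 2 to compound 3 the change is 2-bromophenyl in place of 2,4,5-trichlorophenyl on an oxygen on a saturated carbon. It produced a 4.3-fold lower number from compound 2 to compound 3 (0.63 log units; beyond the scatter).

Compound 4 `NC1=NC2(CCSCC2)N(OCCCOc2ccccc2Br)C(N)=N1` carries the same change onto the core of compound 1: 2-bromophenyl in place of 2,4,5-trichlorophenyl on an oxygen on a saturated carbon. The place of the change reads the same word for word in both pairs, so this is the same change, not merely the same kind.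

The expectation for compound 4 has to rest on the step from compound 2 to compound 3 alone, since compound 1 gives only a limit and no number from which to step. If the same lowering carried over, compound 4 would still start from a value at the limit of this assay, so a number may or may not be reached. The step from compound 1 to compound 4 is expected to be roughly an at least 1.6-fold lower number from compound 1 to compound 4 (0.22 log units; that floor lies within the scatter). Compound 4 is therefore estimated at 60000 nM, with a range from 10000 nM to 300000 nM, and a real chance that only a limit is reported.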

Compound 4, half-maximal inhibitory concentration: 40 nM
For compound 4 the middle estimate is 1500-fold (3.18 log units) above the measured one; measured number outside the range, below it.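

On the core of compound 1, 2-bromophenyl in place of 2,4,5-trichlorophenyl gives an at least 2500-fold lower number from compound 1 to compound 4 (3.39 log units; beyond the scatter) in this assay, a large step. The same change lowers the number on both cores, but its size does not carry from one core to the other: the same change on two cores in this assay, a 4.3-fold lower number (0.63 log units; beyond the scatter) from compound 2 to compound 3 and an at least 2500-fold lower number (3.39 log units; beyond the scatter) from compound 1 to compound 4, at least 580-fold (2.76 log units) apart, beyond the scatter of two such steps. From the compounds shown here alone, compound 1 gives > 100000 nM, which is a limit of the assay and not a number, so the step from it has only a floor and its true size stays unknown, while the comparison rests on one pair per core and does not show why the two steps differ, nor whether the gap would hold for any other aryl group.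

The compounds shown leave open how much of the large step belongs to the loss of the chlorines and how much to the entry of the bromine, a question that an unsubstituted phenyl or a 2-chlorophenyl on both cores would address. Also open, going by these compounds, is whether the dependence on the core persists with another link to the aryl group, such as a longer chain in place of the present one, or with an amine on the aromatic ring.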